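The source may report more compounds than this note shows. Statements on the series, on what has been measured and on what is new or still open speak of the compounds shown alone.

Compound 3 `CCn1c(C(=O)N(C)c2ccccc2)ccc1C(CC)(CC)c1ccc(OCC(=O)C(C)(C)C)c(C)c1` stands highest of the three numbers in an assay on HL-60 cells for agonist activity at vitamin D3 receptor (Homo sapiens), read by microscopy, with a stated time of 96 h; on this read-out higher numbers stand for an effect only at larger amounts of compound and lower numbers for an effect already at smaller amounts: compound 3 gives 18500 nM. Its nearest neighbour is compound 2 `C#CCNC(=O)c1ccc(C(CC)(CC)c2ccc(OCC(=O)C(C)(C)C)c(C)c2)n1CC`, which gives 2200 nM; the furthest is compound 1 `CCN(CC)CCCNC(=O)c1ccc(C(CC)(CC)c2ccc(OCC(=O)C(C)(C)C)c(C)c2)n1CC`, which gives 22 nM. The two steps onto compound 3 are an 8.4-fold higher number from compound 2 to compound 3 (0.92 log units; beyond the scatter) and an 840-fold higher number from compound 1 to compound 3 (2.92 log units; beyond the scatter), both changes of the group on the carbonyl carbon. The remaining step, a 100-fold higher number from compound 1 to compound 2 (2.00 log units; beyond the scatter), changes only the chain on the amide-type nitrogen and is large as well.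

Compound 4 `CCOC(=O)CC(C)OC(=O)c1ccc(C(CC)(CC)c2ccc(OCC(=O)C(C)(C)C)c(C)c2)n1CC` has not yet been measured. It differs from compound 3 by a group of 9 heavy atoms (6 carbon, 3 oxygen; no ring) in place of a group of 8 heavy atoms (7 carbon, 1 nitrogen; one six-membered aromatic ring of carbon only), on a carbonyl carbon; the entering group has no common name and carries three hydrogen-bond acceptors where the methyl(phenyl)amino group had none. Among the compounds with values here, the steps that bear on this change are an 840-fold higher number from compound 1 to compound 3 (2.92 log units; beyond the scatter) and an 8.4-fold higher number from compound 2 to compound 3 (0.92 log units; beyond the scatter), both beyond the scatter, so a shift in this assay is plausible. Within the data shown here, no measured compound carries a group without nitrogen at this carbonyl carbon, so the direction is uncertain. Compound 4 is expected to stay near the upper end of the series, estimated at 8000 nM with a range of 1500 nM to 40000 nM. That estimate corresponds to an expected step of a 2.3-fold lower number from compound 3 to compound 4 (0.36 log units; beyond the scatter), modest at most.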

Compound 4, half-maximal effective concentration: > 50000 nM
Compound 4 gave a limit, no number; the forecaster's own chance of this, stated with the estimate: 15%; middle value at least 6.2-fold (0.79 log units) from the limit.
By their numbers in this assay, from the lowest: compound 1; then compound 2; then compound 3. At a limit, above all of these: compound 4.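

In this assay compound 4 gives > 50000 nM, which is a limit of the assay and not a number. The group of 9 heavy atoms (6 carbon, 3 oxygen; no ring) is the first at this carbonyl carbon without nitrogen, and it gives an at least 2.7-fold higher number from compound 3 to compound 4 (0.43 log units; beyond the scatter), an at least 22-fold higher number from compound 2 to compound 4 (1.35 log units; beyond the scatter) and an at least 2200-fold higher number from compound 1 to compound 4 (3.35 log units; beyond the scatter), so all three nitrogen-bearing groups shown read lower than this one. Heavy-atom count alone does not order the position, as the groups of compound 1 and compound 4 both count 9 heavy atoms yet are separated by the largest step in the series.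

An amide carrying the same chain as compound 4, or a simple methyl ester or a carboxylic acid at this carbonyl carbon, would show whether the shift follows the loss of nitrogen or the rest of the entering group. How far compound 4 lies past its reading also stays open, as it is the only compound at this limit: the limit of > 50000 nM in this assay, at which 1 of the 4 values shown sits.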